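Configuration at the chain carbon: compound 2 to compound 4

A few compounds are considered here, and "the series" means these few. Any claim that something is new, unique, unknown or untested is made for them only; others in the source may bear on it.

Compound 1 (`CC[C@@H](c1ccc(C(=O)O)c(Oc2cccc(Cl)c2)c1F)N1CCC[C@H](n2cc(C)c(=O)[nH]c2=O)C1`), "not determined" (no result reported)
Compound 2 (`Cc1cn([C@H]2CCCN([C@H](CC(C)C)c3ccc(C(=O)O)c(Oc4cccc(Cl)c4)c3F)C2)c(=O)[nH]c1=O`), 84 mL/min/kg
Compound 3 (`CC[C@H](c1ccc(C(=O)O)c(Oc2cccc(Cl)c2)c1F)N1CCC[C@H](n2cc(C)c(=O)[nH]c2=O)C1`), 119 mL/min/kg

Among the compounds with values here, in an ADME assay on the whole organism (strain Wistar) for pharmacokinetics, with Rattus norvegicus as the target, given by the intravenous route (on this read-out lower numbers stand for slow clearance and higher numbers for fast clearance), compound 2 lies within the scatter of the only other number (a 1.4-fold higher number from compound 2 to compound 3 (0.15 log units; within the scatter)). Compound 4 (`Cc1cn([C@H]2CCCN([C@@H](CC(C)C)c3ccc(C(=O)O)c(Oc4cccc(Cl)c4)c3F)C2)c(=O)[nH]c1=O`) keeps every atom and bond of compound 2 (the two compounds have the same atoms and bonds and differ only in configuration as drawn: 1 of 2 stereo elements differ; a stereocentre at a saturated chain carbon is drawn R in compound 2 and S in compound 4). Within the data shown here, the one measured step concerns a different change, and it stays within the scatter. The closest comparison, (the fact that compounds 1 and 3 differ only in the configuration as drawn), yields no size: compound 1 has no number. The estimate therefore rests on compound 2 at 84 mL/min/kg alone. An estimated 1.1-fold lower number from compound 2 to compound 4 (0.02 log units; within the scatter) follows, with no direction favoured and nothing expected beyond the scatter. For compound 4 the expected value is 80 mL/min/kg (estimated range 35 mL/min/kg to 150 mL/min/kg).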

Compound 4, clearance: 38 mL/min/kg
Compound 4: middle estimate off by 2.1-fold (0.32 log units), on the high side, within the range that was stated.
By their numbers in this assay, from the lowest: compound 4; then compounds 2 and 3 (each within the scatter of the next).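

In this assay, within the data shown here, the saturated chain carbon is the first place where a change carries the number beyond the scatter, with a 2.2-fold lower number from compound 2 to compound 4 (0.34 log units; beyond the scatter) as a modest step. No atom or bond changes in this step, so configuration as drawn is the only difference: the fact that compounds 2 and 4 differ only in the configuration as drawn.

As far as these compounds go, whether the smaller chain shows a similar step stays open, as that pair gives no size: the fact that compounds 1 and 3 differ only in the configuration as drawn. Also open, from the compounds shown here alone, is how a cyclopropyl group or a longer chain at this carbon would behave in either configuration.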